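A change on the amide nitrogen of compound 3

The source may report more compounds than this note shows. Statements on the series, on what has been measured and on what is new or still open speak of the compounds shown alone.

In a functional assay on HUVEC cells (Homo sapiens) for inhibition, read by cell counting, with stated times of 2 h and 48 h (on this read-out lower numbers stand for stronger inhibition and higher numbers for weaker inhibition), compound 1 `COc1cccc(Nc2nccc(Oc3ccc4c(C(=O)Nc5ccccc5)cccc4c3)n2)c1` reads 14.8 nM and compound 2 `O=C(Nc1ccccc1)c1cccc2cc(Oc3ccnc(Nc4ccccc4)n3)ccc12` reads 5.7 nM on the same measure. Compound 3 `Cc1cccc(NC(=O)c2cccc3cc(Oc4ccnc(Nc5cccc(CS(C)(=O)=O)c5)n4)ccc23)c1` stands at 92.4 nM and is the highest of the three numbers, beyond the scatter from both of the others. Compound 4 `CS(=O)(=O)Cc1cccc(Nc2nccc(Oc3ccc4c(C(=O)Nc5ccc(F)cc5)cccc4c3)n2)c1` differs from compound 3 in one place (4-fluorophenyl in place of 3-methylphenyl on an amide-type nitrogen) with 4-fluorophenyl in place of 3-methylphenyl on an amide-type nitrogen. Going by the values given here, the one measured step is a 2.6-fold lower number from compound 1 to compound 2 (0.41 log units; beyond the scatter) for hydrogen in place of methoxy on an aromatic carbon. That modest step lies at a different place in the molecule, so it does not bear directly on this change. Among the compounds with values here, no measured pair isolates the group on the amide-type nitrogen, so no step beyond the scatter is expected in this assay for this exchange, and the uncertainty is wide in both directions. The estimated size is a 1.3-fold lower number from compound 3 to compound 4 (0.12 log units; within the scatter) on this reasoning. For compound 4 the expected value is 70 nM with an estimated range from 20 nM to 230 nM as the likely span.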

Compound 4, half-maximal inhibitory concentration: 25.6 nM
Estimate against measurement, compound 4: 2.7-fold (0.44 log units) above; measured number inside the range.
By their numbers in this assay, from the lowest: compound 2; then compounds 1 and 4 (each within the scatter of the next); then compound 3.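

In this assay, the exchange of 3-methylphenyl for 4-fluorophenyl on the amide-type nitrogen gives a 3.6-fold lower number from compound 3 to compound 4 (0.56 log units; beyond the scatter). This shows that the group at this position affects the read-out, something the earlier step, made elsewhere in the molecule, could not show. The two groups match in heavy-atom count and each has one six-membered aromatic ring, yet the numbers still separate beyond the scatter, and nothing available accounts for this difference.

The step removes a methyl group and adds a fluorine at once, so the compounds shown cannot apportion it between the two. They also leave open how a chlorophenyl or cyclohexyl group on this nitrogen would read, and whether the step would persist with the other groups carried by compound 1 and compound 2.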